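The source may hold more compounds than are shown below. What is called first, only, known or untested is meant among the compounds shown, and "the series" means these compounds.

Two compounds from this series carry the same core, a diaryl urea joined through an oxygen bridge to a substituted quinoline, and differ only in the group on the outer benzene ring of the urea. Compound 1 `COc1cc2cc(Oc3ccc(NC(=O)Nc4ccccc4)cc3)c(C)nc2cc1OC` carries hydrogen there, and in a functional assay on RXF 393 cells (Homo sapiens) for inhibition, read by sulforhodamine B assay, with a stated time of 48 h, tested at 10 uM (on this read-out lower numbers stand for a stronger effect and higher numbers for a weaker effect at the one concentration tested), compound 1 gives 76.7%. Compound 2 `COc1cc2cc(Oc3ccc(NC(=O)Nc4ccc(C)cc4)cc3)c(C)nc2cc1OC` carries a methyl in that place, and in this assay compound 2 gives 82.1%. For the measured compounds named here, the single step between them, a number 5.4 percentage points higher from compound 1 to compound 2 (within the scatter), falls inside the scatter of repeated measurements, so the two numbers cannot be told apart; compound 2 stands alongside compound 1 rather than apart from it.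

Compound 3 `COc1cc2cc(Oc3ccc(NC(=O)Nc4ccc(C(F)(F)F)cc4)cc3)c(C)nc2cc1OC` is the next member. The change from compound 2 is trifluoromethyl in place of methyl on an aromatic carbon. Going by the values given here, the only measured step touching this ring position, a number 5.4 percentage points higher from compound 1 to compound 2 (within the scatter), was small, and no step yet shows what a trifluoromethyl does here. Among the compounds with values here, the expectation for compound 3 is therefore a step of about a number 4.1 percentage points lower from compound 2 to compound 3 (within the scatter) in this assay, which is no change beyond the scatter, with a wide uncertainty because the change itself has no measured precedent. Compound 3 is thus estimated at 78% in this assay, within a range from 58% to 95%.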

Compound 3, a percentage reported as activity, at one concentration (the size of the read-out at that concentration, not a potency): 6.29%
Estimate against measurement, compound 3: 71.7 percentage points above; the whole stated range lies above it.
By their numbers in this assay, from the lowest: compound 3; then compounds 1 and 2 (each within the scatter of the next).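

The outer ring looked indifferent to its substituent while only hydrogen and methyl could be compared, but this position turns out to be highly sensitive to what sits there. In this assay, trifluoromethyl in place of methyl gives a number 75.8 percentage points lower from compound 2 to compound 3 (beyond the scatter), and trifluoromethyl in place of hydrogen gives a number 70.4 percentage points lower from compound 1 to compound 3 (beyond the scatter), so a single change on an aromatic carbon, para to a large group, separates a weak effect from a strong one at the one concentration tested. Methyl and trifluoromethyl each replace hydrogen at the same place on the same core, yet only trifluoromethyl stands apart, and nothing available here accounts for that difference between the two groups.

The compounds shown leave open whether this strong effect is particular to trifluoromethyl or is shared by other groups at this place, such as a chlorine atom, a nitrile or a methoxy group. They also leave open how compound 3 would behave across a range of concentrations, since a read-out at a single concentration gives the size of an effect and not a potency.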